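Moving the fluorine and adding a methyl on the styryl ring

The compounds below may be only part of what the source reports. "The series", "measured", "known", "first", "only" and "open" are said of these compounds alone.

Compound 1 `Cc1ccc(CS/C(=C/c2ccccc2F)C(=O)c2ccc(Cl)cc2)cc1` gives 10000 nM in a functional assay on DU-145 cells (Homo sapiens) for inhibition, read by trypan blue exclusion, with a stated time of 96 h; on this read-out lower numbers stand for stronger inhibition of growth and higher numbers for weaker inhibition of growth. Of the two compounds measured, compound 1 has the lower number; compound 2 `O=C(/C(=C\c1ccc(Oc2ccccc2)cc1)Sc1ccc(Br)cc1)c1ccc(Br)cc1` gives 50000 nM in this assay, a gap beyond the usual scatter. Compound 3 `Cc1ccc(CS/C(=C/c2ccc(F)c(C)c2)C(=O)c2ccc(Cl)cc2)cc1` differs from compound 1 by 4-fluoro-3-methylphenyl in place of 2-fluorophenyl on a double-bonded chain carbon bound to a double-bonded chain carbon. Within the data shown here, no measured pair shows the effect of such a change, so only a small step, likely none beyond the scatter, is expected no change at the digits printed from compound 1 to compound 3 (within the scatter). Compound 3 is therefore estimated at 10000 nM, within 3000 nM to 40000 nM.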

Compound 3, concentration for 50% growth inhibition: 25000 nM
Compound 3: middle estimate off by 2.5-fold (0.40 log units), on the low side; low and high end bracket the measured number.
By their numbers in this assay, from the lowest: compound 1; then compounds 3 and 2 (each within the scatter of the next).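

In this assay, among these compounds, 4-fluoro-3-methylphenyl in place of 2-fluorophenyl on a double-bonded chain carbon bound to a double-bonded chain carbon gives a 2.5-fold higher number from compound 1 to compound 3 (0.40 log units; beyond the scatter), the first step in this set that differs in one place, and it shows that this position responds to the change, though only modestly. Nothing available gives a reason for this step. The compounds shown leave open whether the changed place of the fluorine or the added methyl carries the step. They also leave open what an amine or a carboxylic acid on this phenyl ring would give.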